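Nitro for methyl on the benzamide ring: cytotoxicity notes

The source may report more compounds than this note shows. Statements on the series, on what has been measured and on what is new or still open speak of the compounds shown alone.

Compound 1 `CC(=O)Oc1ccc(/C=C/S(=O)(=O)CCc2ccc(NC(=O)c3ccc(C)cc3)cc2)cc1OC(C)=O` and compound 2 `CC(=O)Oc1ccc(/C=C/S(=O)(=O)CCc2ccc(NC(=O)c3ccc([N+](=O)[O-])cc3)cc2)cc1OC(C)=O` share one core; compound 3 `Cc1ccc(C(=O)Nc2ccc(CCS(=O)(=O)/C=C/c3ccc(O)c(O)c3)cc2)cc1` and compound 4 `O=C(Nc1ccc(CCS(=O)(=O)/C=C/c2ccc(O)c(O)c2)cc1)c1ccc([N+](=O)[O-])cc1` share another. The difference between the two cores is not broken down here. In an ADME assay on TZM cells (Homo sapiens) for cytotoxicity, read by CCK-8 assay, with a stated time of 2 days (on this read-out higher numbers stand for lower toxicity in this test and lower numbers for higher toxicity in this test), compound 1 gives 177000 nM and compound 2 gives 160000 nM; the change between them is nitro in place of methyl on an aromatic carbon, and it made a 1.1-fold lower number from compound 1 to compound 2 (0.04 log units; within the scatter). In this assay compound 3 gives 168000 nM, within the scatter of both earlier numbers. Compound 4 is not yet measured; it differs from compound 3 by nitro in place of methyl on an aromatic carbon, the same change at the same place. For compound 4 the expected step is a 1.1-fold lower number from compound 3 to compound 4 (0.03 log units; within the scatter). Among the measured compounds shown here, that expectation rests on the single measured pair, where a 1.1-fold lower number from compound 1 to compound 2 (0.04 log units; within the scatter) stayed within the scatter, so the range is kept wide. The estimate for compound 4 is 155000 nM, with 95000 nM to 250000 nM as its span.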

Compound 4, half-maximal cytotoxic concentration: 483000 nM
Beside the measured number, compound 4's estimate is 3.1-fold (0.49 log units) below it; the measured number lies above the stated range.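

Nitro in place of methyl does not carry over as a fixed step between these two cores in this assay: the same change on two cores in this assay, a 1.1-fold lower number (0.04 log units; within the scatter) from compound 1 to compound 2 and a 2.9-fold higher number (0.46 log units; beyond the scatter) from compound 3 to compound 4, 3.2-fold (0.50 log units) apart, beyond the scatter of two such steps. The new step is a 2.9-fold higher number from compound 3 to compound 4 (0.46 log units; beyond the scatter) and points towards lower toxicity in this test, whereas the earlier pair stayed within the scatter. This shows that the outcome of the change depends on the core for these two pairs, but it does not show which feature of the cores is responsible, and two pairs set no rule for other cores.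

Which part of the difference between the cores goes with the split stays open. Also open, from the compounds shown here alone, is whether an amine or a carboxylic acid at the same place on the ring would separate the two cores in the same way.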